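From 4-methylphenyl to 3-bromophenyl on a shared core

A few compounds are considered here, and "the series" means these few. Any claim that something is new, unique, unknown or untested is made for them only; others in the source may bear on it.

Among the compounds with values here, in a functional assay on HepG2 cells (Homo sapiens) for inhibition, read by MTT assay, with a stated time of 24 h (on this read-out lower numbers stand for stronger inhibition and higher numbers for weaker inhibition), compound 3 (`Cc1ccc(-n2cc(CN3C(=O)C[C@@H]4CC[C@@]3(C)C4(C)C)nn2)cc1`) gives 480 nM, the highest of the three numbers so far, which makes it the weakest inhibitor of the set. Compound 1 (`CC1(C)[C@H]2CC[C@]1(C)N(Cc1cn(-c3ccccc3Br)nn1)C(=O)C2`) gives 150 nM, and compound 2 (`CC1(C)[C@H]2CC[C@]1(C)N(Cc1cn(-c3ccccc3)nn1)C(=O)C2`) gives 90 nM.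

Compound 4 (`CC1(C)[C@H]2CC[C@]1(C)N(Cc1cn(-c3cccc(Br)c3)nn1)C(=O)C2`) has not yet been measured. Its difference from compound 3 is this: 3-bromophenyl in place of 4-methylphenyl on an aromatic nitrogen. In words, 3-bromophenyl stands in place of 4-methylphenyl on an aromatic nitrogen.

Within the data shown here, three measured steps bear on this change. Replacing bromo with hydrogen gave a 1.7-fold lower number from compound 1 to compound 2 (0.22 log units; within the scatter), whereas adding the methyl gave a 5.3-fold higher number from compound 2 to compound 3 (0.73 log units; beyond the scatter). Exchanging 2-bromophenyl for 4-methylphenyl gave a 3.2-fold higher number from compound 1 to compound 3 (0.51 log units; beyond the scatter). Among the measured compounds shown here, no measured compound carries 3-bromophenyl, so compound 1, at 150 nM, is only the closest guide.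

A modest fall in the number is therefore expected, with the estimated change being a 2.7-fold lower number from compound 3 to compound 4 (0.43 log units; beyond the scatter). The estimate for compound 4 is 180 nM, with an expected range of 70 nM to 450 nM.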

Compound 4, half-maximal inhibitory concentration: 20 nM
For compound 4 the middle estimate is 9.0-fold (0.95 log units) above the measured one; the measured number lies below the stated range.
By their numbers in this assay, from the lowest: compound 4; then compounds 2 and 1 (each within the scatter of the next); then compound 3.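

In this assay, within the data shown here, the aryl group on the aromatic nitrogen proves able to shift the number far more than the earlier compounds showed: 3-bromophenyl in place of 4-methylphenyl gives the largest step in the set (a 24-fold lower number from compound 3 to compound 4 (1.38 log units; beyond the scatter)). The effect of bromo also depends on where it sits on the phenyl ring: 2-bromophenyl was not separated from plain phenyl, yet 3-bromophenyl stands clearly apart from phenyl (a 4.5-fold lower number from compound 2 to compound 4 (0.65 log units; beyond the scatter)) and from 2-bromophenyl (a 7.5-fold lower number from compound 1 to compound 4 (0.88 log units; beyond the scatter)). Nothing available explains why this one group stands out.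

The step from 4-methylphenyl changes both the substituent and its place on the ring, and the compounds shown do not separate those two changes. As far as these compounds go, how 3-methylphenyl, 4-bromophenyl or 3-chlorophenyl would compare remains open.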